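The compounds below may be only part of what the source reports. "The series", "measured", "known", "first", "only" and "open" are said of these compounds alone.

Measured compounds:

Compound 1 `CC(C)c1onc(-c2c(Cl)cccc2Cl)c1COc1ccc(N(C)Cc2cccc(C(=O)NS(C)(=O)=O)c2)c(C(F)(F)F)n1` gives 48 nM in an assay on isolated protein for agonist activity at Bile acid receptor (Homo sapiens), read by FRET; on this read-out lower numbers stand for an effect already at smaller amounts and higher numbers for an effect only at larger amounts of compound.
Compound 2 `CN(Cc1ccc(C(=O)NCCS(=O)(=O)O)cc1)c1ccc(OCc2c(-c3c(Cl)cccc3Cl)noc2C2CC2)nc1C(F)(F)F` gives 14 nM in this assay.
Compound 3 `CC(Nc1ccc(C(=O)O)cc1)c1ccc(OCc2c(-c3c(Cl)cccc3Cl)noc2C2CC2)nc1C(F)(F)F` gives 101 nM in this assay.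

Among these three numbers compound 3 stands highest. The nearest of the other two is compound 1, whose number is lower by a margin beyond the usual scatter, and the furthest is compound 2, whose number is lower still, also beyond the scatter. Compound 4 `CC(Oc1cccc(C(=O)O)c1)c1ccc(OCc2c(-c3c(Cl)cccc3Cl)noc2C2CC2)nc1C(F)(F)F` is not yet measured. It differs from compound 3 in one place: 3-carboxyphenoxy in place of (4-carboxyphenyl)amino on a saturated chain carbon bound to an aromatic carbon and a saturated chain carbon. Within the data shown here, no pair of measured compounds isolates this particular change, so neither its direction nor its size can be read from the existing numbers. In the absence of such a precedent, the step from compound 3 to compound 4 is expected to be modest, a 1.5-fold higher number from compound 3 to compound 4 (0.17 log units; within the scatter), and could fall on either side of the scatter. For compound 4 in this assay the estimate is 150 nM, with a plausible range from 45 nM to 500 nM.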

Compound 4, half-maximal effective concentration: 155 nM
Beside the measured number, compound 4's estimate is 1.0-fold (0.01 log units) below it; the range from low to high includes it.
By their numbers in this assay, from the lowest: compound 2; then compound 1; then compounds 3 and 4 (each within the scatter of the next).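

Among these compounds, the first comparison at this position comes from this assay, where 3-carboxyphenoxy in place of (4-carboxyphenyl)amino on a saturated chain carbon bound to an aromatic carbon and a saturated chain carbon gives a 1.5-fold higher number from compound 3 to compound 4 (0.19 log units; within the scatter). The exchange changes the linking atom from nitrogen to oxygen and moves the carboxylic acid from the 4 to the 3 position of the ring, yet the two compounds remain within the scatter of each other, so this one step cannot separate the two alterations. Nothing available explains this result.

On these data alone, it remains open how 4-carboxyphenoxy or (3-carboxyphenyl)amino would read at this carbon, either of which would separate the link from the placement of the acid. Also open, as far as these compounds go, is whether a tetrazole could stand in for the carboxylic acid here.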